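The compounds below may be only part of what the source reports. "The series", "measured", "known", "first", "only" and "open" are said of these compounds alone.

Notes on the series. Compound 1 `COc1cc2ncnc(Nc3ccc(F)c(Cl)c3)c2cc1NC(=O)/C=C/c1ccccc1[N+](=O)[O-]`, compound 2 `N#Cc1ccc(/C=C/C(=O)Nc2cc3c(Nc4ccc(F)c(Cl)c4)ncnc3cc2O[C@H]2CCOC2)cc1`, compound 3 `COc1cc2ncnc(Nc3ccc(F)c(Cl)c3)c2cc1NC(=O)/C=C/c1ccc(C#N)cc1` and compound 4 `O=C(/C=C/c1ccc(Br)cc1)Nc1cc2c(Nc3ccc(F)c(Cl)c3)ncnc2cc1O[C@H]1CCOC1` share one core and differ only in the outer substituents. In a functional assay on PC-3 cells (Homo sapiens) for cytotoxicity, read by MTT assay, with a stated time of 72 h (on this read-out higher numbers stand for weaker inhibition and lower numbers for stronger inhibition), compound 1 gives 14300 nM, compound 2 gives 36600 nM and compound 3 gives "not active" (no number reported), with no single number reported. Of the two numbers in this assay compound 2 holds the higher one; its gap to compound 1 lies beyond the scatter. Compound 4 differs from compound 2 by bromo in place of cyano on an aromatic carbon. For the measured compounds named here, no step between two measured compounds that differ in a single place is available, so nothing here fixes the size of this change. For compound 4 the step expected in this assay is a 1.5-fold lower number from compound 2 to compound 4 (0.17 log units; within the scatter), small and toward a lower number. Compound 4 is expected to give 25000 nM in this assay, within 8000 nM to 80000 nM.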

Compound 4, half-maximal inhibitory concentration: 28200 nM
For compound 4 the middle estimate is 1.1-fold (0.05 log units) below the measured one; low and high end bracket the measured number.
By their numbers in this assay, from the lowest: compounds 1, 4 and 2 (each within the scatter of the next, the first and the last beyond it).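

Bromo in place of cyano on an aromatic carbon para to a large group gives a 1.3-fold lower number from compound 2 to compound 4 (0.11 log units; within the scatter) in this assay. For the compounds shown here, this is the first step between compounds that differ in one place, and at this position it does not separate the two groups, even though one heavy atom enters where two leave. No measurement on hand accounts for this result.

Going by these compounds, whether an amine or a carboxylic acid on this same carbon would give a step beyond the scatter remains open. The same holds for a longer chain there.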